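The source may hold more compounds than are shown below. What is called first, only, known or untested is meant among the compounds shown, and "the series" means these compounds.

Measured so far:
- Compound 1 `CCS(=O)(=O)c1ccc2c(c1)C(C)=CN(C)C(=O)[C@@H]2C`: >= 131 ug/mL (a limit)
- Compound 2 `CCS(=O)(=O)c1ccc2c(c1)C(c1cnn(C)c1)=CN(C)C(=O)[C@@H]2C`: >= 222 ug/mL (a limit)

In a physicochemical assay for solubility (on this read-out higher numbers stand for higher solubility and lower numbers for lower solubility), compound 2 has only a limit and no number: >= 222 ug/mL. Compound 1 also has only a limit: >= 131 ug/mL.

Compound 3 `CCOc1ccc2c(c1)C(c1cnn(C)c1)=CN(C)C(=O)[C@@H]2C` carries ethoxy in place of ethylsulfonyl on an aromatic carbon. Going by the values given here, the only measured step is a step that the two limits leave unreadable from compound 1 to compound 2. That step puts 1-methyl-1H-pyrazol-4-yl in place of methyl on a double-bonded ring carbon, at a different place from the present change, and it offers no size to carry over. A downward step of uncertain size is therefore expected in this assay, though this rests on little evidence, and the result may again be only a limit. The estimate means an expected at least 2.2-fold lower number from compound 2 to compound 3 (0.34 log units; beyond the scatter). The estimated value for compound 3 is 100 ug/mL, with an expected range of 25 ug/mL to 240 ug/mL.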

Compound 3, solubility: 143 ug/mL
For compound 3 the middle estimate is 1.4-fold (0.16 log units) below the measured one; measured number inside the range.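

In this assay, going by these compounds alone, compound 3 gives 143 ug/mL, the first value in this set that is a number rather than a limit, and the first read-out of a change on the aromatic carbon that carries ethylsulfonyl in compound 2. Putting ethoxy in place of ethylsulfonyl there gives an at least 1.5-fold lower number from compound 2 to compound 3 (0.19 log units; that floor lies within the scatter), so the data fix only a floor for this step, and that floor does not clear the scatter. The true size of the step stays unknown because compound 2 has only a limit: the limit of >= 222 ug/mL in this assay, at which 1 of the 3 values shown sits.

The step that changes methyl to 1-methyl-1H-pyrazol-4-yl still cannot be read. As far as these compounds go, what an amine, a carboxylic acid or a longer chain would give on this aromatic carbon also stays open.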